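Restoring a carbon-only ring in a biphenyl cyclopropanecarboxamide

The source may hold more compounds than are shown below. What is called first, only, known or untested is meant among the compounds shown, and "the series" means these compounds.

Measured compounds:
compound 1, `N[C@H](CN(C(=O)[C@@H]1C[C@H]1c1ccccc1)c1ccc(-c2ccccc2)cc1)C1CCCCC1`, 0.66 nM
compound 2, `CC(C)C[C@H](N)CCN(C(=O)[C@@H]1C[C@H]1c1ccccc1)c1ccc(-c2ccccc2)cc1`, 3 nM
compound 3, `CC(C)C[C@H](N)CN(C(=O)[C@@H]1C[C@H]1c1ccccc1)c1ccc(-c2cccnc2)cc1`, 10000 nM

In a functional assay for agonist activity at G protein-coupled receptor 88 (Homo sapiens), read by HTRF and cAMP accumulation (on this read-out lower numbers stand for an effect already at smaller amounts and higher numbers for an effect only at larger amounts of compound), compound 3 gives the highest number of the three: compound 2 sits far lower and compound 1 lower still, both gaps well beyond the scatter. Compound 4, `Cc1cccc(-c2ccc(N(C[C@@H](N)CC(C)C)C(=O)[C@@H]3C[C@H]3c3ccccc3)cc2)c1`, is obtained from compound 3 by 3-methylphenyl in place of pyridin-3-yl on an aromatic carbon. Within the data shown here, no measured step changes this ring alone, so the step cannot be read directly. Among the measured compounds shown here, the only step on record, a 4.5-fold higher number from compound 1 to compound 2 (0.66 log units; beyond the scatter), concerns the amine-bearing chain and was modest. What the values show is that compound 1 and compound 2, which both carry a carbon-only ring at this position, give low numbers, while compound 3 with pyridin-3-yl gives a very high one. Compound 4 is therefore expected to move strongly back toward compound 1 and compound 2, with a 1000-fold lower number from compound 3 to compound 4 (3.00 log units; beyond the scatter). For compound 4 the estimate in this assay is 10 nM, within 1 nM to 100 nM.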

Compound 4, half-maximal effective concentration: 1200 nM
Compound 4: middle estimate off by 120-fold (2.08 log units), on the low side, outside the stated range (above it).
By their numbers in this assay, from the lowest: compound 1; then compound 2; then compound 4; then compound 3.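

In this assay, among these compounds, 3-methylphenyl in place of pyridin-3-yl on this aromatic carbon gives an 8.3-fold lower number from compound 3 to compound 4 (0.92 log units; beyond the scatter), the first direct reading of a change at this ring. The position therefore responds to the swap, but the step is modest, and on the 2-amino-4-methylpentyl chain compound 4 with this carbon-only ring still gives 1200 nM. No measurement at hand accounts for the size of this step.

The compounds shown leave open how plain phenyl, 4-methylphenyl or 3-methoxyphenyl would stand at this position on the same chain. The part played by the added methyl group therefore cannot be separated from that of the ring nitrogen it replaces.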